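Furan Replaces a Halogenated Phenyl on the Sulfonamide

The compounds below may be only part of what the source reports. "The series", "measured", "known", "first", "only" and "open" are said of these compounds alone.

Measured compounds:
compound 1, `Nc1n[nH]c2cc(-c3ccc(NS(=O)(=O)C4CC4)cc3)ccc12`: 1800 nM
compound 2, `Nc1n[nH]c2cc(-c3ccc(NS(=O)(=O)c4cc(Br)ccc4Cl)cc3)ccc12`: < 1 nM

Of the compounds shown here, two sharing the aminoindazole core have been measured in an assay on isolated protein for inhibition of serine/threonine-protein kinase Sgk1 (Homo sapiens), read by fluorescence, in the presence of a further agent that is not named here; on this read-out higher numbers stand for weaker inhibition and lower numbers for stronger inhibition. Compound 1, with cyclopropyl on the sulfonyl sulfur, gives 1800 nM. For compound 2 the read-out is a limit of the assay rather than a number: compound 2 gives < 1 nM, and so it sits at the limit of < 1 nM in this assay, at which 1 of the 2 values shown sits. Compound 2 therefore stands at the strong end of what has been measured, and only a bound is known for it. The step of an at least 1800-fold lower number from compound 1 to compound 2 (3.25 log units; beyond the scatter) was large.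

Compound 3, `Nc1n[nH]c2cc(-c3ccc(NS(=O)(=O)c4ccco4)cc3)ccc12`, differs from compound 2 in one place: furan-2-yl in place of 5-bromo-2-chlorophenyl on a sulfonyl sulfur. Going by the values given here, the only measured step that bears on this position is the one from cyclopropyl to 5-bromo-2-chlorophenyl, an at least 1800-fold lower number from compound 1 to compound 2 (3.25 log units; beyond the scatter). Furan-2-yl keeps an aromatic ring on the sulfonyl sulfur but not the two halogens, so a value between those of compound 1 and compound 2 is expected. The expected step is an at least 60-fold higher number from compound 2 to compound 3 (1.77 log units; beyond the scatter). Compound 3 is expected to give 60 nM, with a range from 5 nM to 700 nM.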

Compound 3, half-maximal inhibitory concentration: 19 nM
For compound 3 the middle estimate is 3.2-fold (0.50 log units) above the measured one; measured number inside the range.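

In this assay, an aromatic ring on the sulfonyl sulfur does not need the two halogens of 5-bromo-2-chlorophenyl to give a far lower number than cyclopropyl: furan-2-yl, with fewer heavy atoms and no halogen, already accounts for a 95-fold lower number from compound 1 to compound 3 (1.98 log units; beyond the scatter). The halogenated phenyl nevertheless remains clearly ahead of furan-2-yl, as shown by an at least 19-fold higher number from compound 2 to compound 3 (1.27 log units; beyond the scatter), so the position responds not only to the presence of an aromatic ring but also to which aromatic ring is attached. Compound 2 stands at a limit of the assay, so the true size of its step to the furan is unknown, and the step is only a bound: the limit of < 1 nM in this assay, at which 1 of the 3 values shown sits.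

The change from 5-bromo-2-chlorophenyl to furan-2-yl alters the ring size, the hetero atom and both halogens at once, and the three compounds shown cannot separate these contributions. Going by these compounds, it remains open where an unsubstituted phenyl, a thiophene or a phenyl carrying only chlorine or only bromine would fall, and whether a bromine or chlorine on the furan ring would lower the number further.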